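Benzyl Ester in Place of the Acid of Compound 2

The compounds below may be only part of what the source reports. "The series", "measured", "known", "first", "only" and "open" are said of these compounds alone.

Of the compounds shown here, two have been measured in a functional assay on cells (Oocyte) for inhibition of Voltage-dependent T-type calcium channel subunit alpha-1H (Homo sapiens), tested at 100 uM; on this read-out lower numbers stand for less inhibition and higher numbers for more inhibition at the one concentration tested (going by the name of the read-out). Compound 1 `CN1CCN(C2=Nc3ccccc3C(CC(=O)O)N2c2ccccc2)CC1` gives 15% in this assay, and compound 2 `O=C(O)CC1c2ccccc2N=C(c2ccccc2)N1c1ccccc1` gives 7.2% there. Among the measured compounds shown here, compound 2 stands alongside compound 1 on these numbers, since the single measured step, a number 7.8 percentage points lower from compound 1 to compound 2 (within the scatter), lies within the scatter, so the two cannot be told apart. Compound 3 `O=C(CC1c2ccccc2N=C(c2ccccc2)N1c1ccccc1)OCc1ccccc1` has not yet been measured. It differs from compound 2 in one place: benzyl in place of hydrogen on an oxygen next to a carbonyl group. For the measured compounds named here, no measured step touches this oxygen or this kind of exchange; the step from compound 1 to compound 2 concerns a different position on the shared core. The known numbers therefore give no ground for a shift in either direction, and the step of a number 4.8 percentage points higher from compound 2 to compound 3 (within the scatter) is expected to stay within the scatter, with a wide range. Compound 3 is thus expected to give 12% in this assay, between 0% and 35%.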

Compound 3, a percentage reported as inhibition, at one concentration (the size of the read-out at that concentration, not a potency): 14.2%
Estimate against measurement, compound 3: 2.2 percentage points below; low and high end bracket the measured number.
By their numbers in this assay, from the lowest: compounds 2, 3 and 1 (each within the scatter of the next).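

Benzyl in place of hydrogen on an oxygen next to a carbonyl group is the first exchange tested at this position, and in this assay it gives a number 7 percentage points higher from compound 2 to compound 3 (within the scatter) as the step. Compound 2 and compound 3 therefore cannot be told apart on this read-out, which shows that the carboxy group and the benzyloxycarbonyl group at this place give numbers within the usual scatter of each other. Nothing available here accounts for this result.

On these data alone, whether a methyl ester, a primary amide or an amine at this place would also stay within the scatter remains open. So does whether a longer chain between the oxygen and the benzene ring would yield a number that can be told apart from those of compound 2 and compound 3.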